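Dimethylphenyl analogue of the chromenone series

The source may report more compounds than this note shows. Statements on the series, on what has been measured and on what is new or still open speak of the compounds shown alone.

Measured so far, in a functional assay on KB cells (Homo sapiens) for antiproliferative activity, read by sulforhodamine B assay, with a stated time of 3 days; on this read-out higher numbers stand for an effect only at larger amounts of compound and lower numbers for an effect already at smaller amounts:
compound 1, `CCCCc1ccc(-c2cc(=O)c3c(o2)C(CC)(CC)C(=O)C(CC)=C3O)cc1`, gives 111 uM
compound 2, `CCC1=C(O)c2c(oc(-c3ccc(OC(F)(F)F)cc3)cc2=O)C(CC)(CC)C1=O`, gives 36.5 uM
compound 3, `CCC1=C(O)c2c(oc(-c3ccccc3C)cc2=O)C(CC)(CC)C1=O`, gives 40.9 uM

Compound 3 stands second highest of the three numbers in this assay. Its nearest neighbour is compound 2, whose number is lower by an amount within the scatter, so the two cannot be ordered. Compound 1 lies further away, with a higher number beyond the scatter. Among the compounds with values here, the only step counted between measured compounds is the one from compound 1 to compound 2, a 3.0-fold lower number from compound 1 to compound 2 (0.48 log units; beyond the scatter), a change of one aromatic substituent for another.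

Compound 4, `CCC1=C(O)c2c(oc(-c3cccc(C)c3C)cc2=O)C(CC)(CC)C1=O`, is not yet measured. It differs from compound 3 by methyl in place of hydrogen on an aromatic carbon. Within the data shown here, no measured step concerns adding a methyl to the aromatic ring, and the one step available, trifluoromethoxy in place of butyl, is a different change at a different place, so it gives no direct guide. With nothing in the set pointing either way, compound 4 is expected to stay close to compound 3, the step of a 1.0-fold lower number from compound 3 to compound 4 (0.01 log units; within the scatter) being expected to fall within the scatter.

For compound 4 the estimate in this assay is 40 uM, with a range from 18 uM to 90 uM.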

Compound 4, concentration for half-maximal effect: 3.1 uM
Compound 4: middle estimate off by 13-fold (1.11 log units), on the high side; the measured number lies below the stated range.
By their numbers in this assay, from the lowest: compound 4; then compounds 2 and 3 (each within the scatter of the next); then compound 1.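

In this assay, going from 2-methylphenyl to 2,3-dimethylphenyl gives a 13-fold lower number from compound 3 to compound 4 (1.12 log units; beyond the scatter), so this aromatic carbon is a sensitive point on the ring, although the entering group is one carbon with no ring, no hydrogen-bond donors or acceptors, and no net charge. Within the data shown here, this step is larger than the only earlier step, a 3.0-fold lower number from compound 1 to compound 2 (0.48 log units; beyond the scatter), which replaced butyl with trifluoromethoxy on an aromatic carbon and gave no information about this carbon or about adding a methyl to the ring. The new methyl sits ortho to a methyl group and meta to a large group, and the shift is established for this one substitution on the 2-methylphenyl ring; nothing available here explains the size of the step.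

As far as these compounds go, it remains open whether the shift is specific to methyl or would also appear with another group on this carbon, such as ethyl, methoxy, chlorine or an amine. From the compounds shown here alone, it is also open whether the methyl on this carbon would have the same effect without the existing methyl on the ring, and whether the same addition would carry over to the butyl-substituted or trifluoromethoxy-substituted rings.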